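The compounds below may be only part of what the source reports. "The series", "measured", "known", "first", "only" and "open" are said of these compounds alone.

Values in a functional assay on SEM cells (Homo sapiens) for cytotoxicity, read by MTT assay, with a stated time of 72 h; a higher number here means a weaker inhibitor, a lower number a stronger inhibitor:
- compound 1 `COC(=O)c1sc2cc(OC)ccc2c1Nc1cc(OC)c(OC)c(OC)c1`: 10.3 nM
- compound 2 `CCOC(=O)c1sc2ccccc2c1Nc1cc(OC)c(OC)c(OC)c1`: 1900 nM
- compound 3 `COC(=O)c1sc2cc(C)ccc2c1Nc1cc(OC)c(OC)c(OC)c1`: 0.7 nM

Compound 3 has the lowest number of the three. Compound 4 `CCOC(=O)c1sc2cc(C)ccc2c1Nc1cc(OC)c(OC)c(OC)c1` differs from it by methyl in place of hydrogen on a saturated chain carbon bound to an oxygen next to a carbonyl group, that is, methoxycarbonyl to ethoxycarbonyl. Within the data shown here, no measured step covers this change. Among the measured compounds shown here, the only measured step, a 15-fold lower number from compound 1 to compound 3 (1.17 log units; beyond the scatter), is methyl in place of methoxy on an aromatic carbon, a different change. Compound 2 already carries ethoxycarbonyl and reads 1900 nM, but it also lacks the aromatic methyl of compound 3, so its value cannot separate the two changes. A rise in this assay beyond the scatter is expected, though well short of that whole gap. The expected step is an 11-fold higher number from compound 3 to compound 4 (1.06 log units; beyond the scatter). The estimate for compound 4 is 8 nM, with an expected range of 1.5 nM to 60 nM.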

Compound 4, half-maximal inhibitory concentration: 1.5 nM
Compound 4: middle estimate off by 5.3-fold (0.73 log units), on the high side, and the stated range covers the measured number.
By their numbers in this assay, from the lowest: compound 3; then compound 4; then compound 1; then compound 2.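

In this assay the change from methoxycarbonyl to ethoxycarbonyl, read with the aromatic methyl held in place, is modest (a 2.1-fold higher number from compound 3 to compound 4 (0.33 log units; beyond the scatter)). With ethoxycarbonyl held in place, the aromatic methyl accounts for a far larger step (a 1300-fold lower number from compound 2 to compound 4 (3.10 log units; beyond the scatter)), so the high number of compound 2 goes with the missing methyl rather than with the ester. Nothing available explains either step. From the compounds shown here alone, whether a longer chain such as propoxycarbonyl, or a carboxylic acid, keeps the number this low remains open. Also open, going by these compounds, is how ethoxycarbonyl behaves with methoxy on the aromatic carbon.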